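The compounds below may be only part of what the source reports. "The series", "measured", "known", "first", "only" and "open" are said of these compounds alone.

Measured compounds:
compound 1, `O=C(O[C@H]1C[C@H](n2cc(F)c(=O)[nH]c2=O)O[C@@H]1COP(=O)(O)Oc1cccnc1)c1ccccc1` — 710 nM
compound 2, `O=c1[nH]c(=O)n([C@H]2C[C@H](O)[C@@H](COP(=O)(O)Oc3ccccc3)O2)cc1F` — 33700 nM

Both numbers come from a functional assay on U-87MG ATCC cells for cytotoxicity against U-87 MG (Homo sapiens), read by MTT assay, with a stated time of 48 h; a lower number here means a stronger inhibitor, a higher number a weaker inhibitor. Compound 2 stands with the higher of the two numbers, and its gap to compound 1 lies well beyond the usual scatter. Within the data shown here, compound 1 and compound 2 differ from each other in more than one place, so the gap between them cannot be tied to any single change; the two values show only that compound 1 sits far lower.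

Compound 3, `O=c1[nH]c(=O)n([C@H]2C[C@H](O)[C@@H](COP(=O)(O)Oc3cccnc3)O2)cc1F`, has not yet been measured in this assay. It differs from compound 2 in one place: pyridin-3-yl in place of phenyl on an oxygen. Among the measured compounds shown here, no measured pair shows this change on its own. Compound 1 also carries pyridin-3-yl on that oxygen and has the far lower number, but it differs from compound 2 elsewhere as well, so how much of that gap belongs to this change is open. A modest step toward a lower number is expected for compound 3, a 2.8-fold lower number from compound 2 to compound 3 (0.45 log units; beyond the scatter), perhaps just beyond the scatter. Compound 3 is estimated at 12000 nM, with a range from 3500 nM to 35000 nM.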

Compound 3, half-maximal inhibitory concentration: 39800 nM
Compound 3: the middle estimate sits 3.3-fold (0.52 log units) below what was measured; measured number outside the range, above it.
By their numbers in this assay, from the lowest: compound 1; then compounds 2 and 3 (each within the scatter of the next).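

In this assay, the step at the oxygen bound to phosphorus is now isolated: with pyridin-3-yl in place of phenyl there is a 1.2-fold higher number from compound 2 to compound 3 (0.07 log units; within the scatter), so this change on its own leaves the number where it was on this core, which bears a free hydroxyl on the saturated carbon. The benzoyl position, which the earlier pair could not separate out, is now isolated too, since hydrogen in place of benzoyl on an oxygen on a saturated carbon gives a 56-fold higher number from compound 1 to compound 3 (1.75 log units; beyond the scatter), a large step with pyridin-3-yl held fixed throughout. What is shown therefore places the large difference in this series at the benzoyl position and not at the aryl group on the phosphate, although nothing at hand accounts for either step.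

The compounds shown leave open whether benzoyl has the same size of effect when phenyl rather than pyridin-3-yl sits on the phosphate oxygen. They also leave open whether a smaller acetyl group, a longer acyl chain or a carbamate on that same oxygen would read like benzoyl or like the free hydroxyl.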